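Cyano for ethyl on the aryl ether of compound 1

This account rests on a few compounds, and the source may have more. Where it says the series, first, only, none or still open, it means among the compounds named here.

Measured compounds:
compound 1 `CCc1ccc(OCC(=O)N(CC)Cc2cccs2)cc1` – 67 nM
compound 2 `Cc1ccc(OCC(=O)N(Cc2cccs2)c2cnn(C)c2)cc1` – 63000 nM

In an assay on HEK293 cells for agonist activity at transient receptor potential cation channel subfamily M member 8 (Homo sapiens), read by fluorescence and calcium flux, with a stated time of 15 min (a lower number here means that less compound is needed, a higher number that more compound is needed for the effect), compound 1 gives 67 nM, the lowest of the two numbers measured. Within the data shown here, compound 2 gives 63000 nM, a gap to compound 1 far beyond the scatter, though the two differ in several places and no single step connects them. Compound 3 `CCN(Cc1cccs1)C(=O)COc1ccc(C#N)cc1` differs from compound 1 in one place: cyano in place of ethyl on an aromatic carbon, on an aromatic carbon of a six-membered aromatic ring of carbon only. Among the measured compounds shown here, no measured step covers this change, so the expectation rests on compound 1 alone, with the direction and size open. A moderate rise in this assay is expected, giving a 7.5-fold higher number from compound 1 to compound 3 (0.87 log units; beyond the scatter). Compound 3 is estimated at 500 nM, within a range of 70 nM to 4000 nM.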

Compound 3, half-maximal effective concentration: 1990 nM
The estimate for compound 3 lay 4.0-fold (0.60 log units) below the measured number; measured number inside the range.
By their numbers in this assay, from the lowest: compound 1; then compound 3; then compound 2.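

Among these compounds, the first one-place step at this position shows that the group on the aromatic carbon, para to a large group, matters: in this assay, cyano in place of ethyl gives a 30-fold higher number from compound 1 to compound 3 (1.47 log units; beyond the scatter). The two groups have the same heavy-atom count, while cyano brings a hydrogen-bond acceptor that ethyl lacks. Nothing at hand gives a reason for the step. The compounds shown leave open whether other groups here, such as methoxy, chlorine or a longer chain like propyl, would stay close to ethyl or to cyano.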